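The source may report more compounds than this note shows. Statements on the series, on what has been measured and on what is new or still open speak of the compounds shown alone.

Three compounds share one core and differ only in what sits on an amine nitrogen in a ring. Compound 1 `CN(C[C@H]1Cc2c(cccc2N2CCN(Cc3ccccn3)CC2)CN1)[C@H]1CCCc2cccnc21` carries a (pyridin-2-yl)methyl there and in a functional assay on CCRF-CEM cells for antagonist activity at C-X-C chemokine receptor type 4 (Homo sapiens), read by calcium flux, with stated times of 25 min and 90 s (on this read-out higher numbers stand for weaker inhibition and lower numbers for stronger inhibition), compound 1 gives 4.47 nM. Compound 2 `CN(C[C@H]1Cc2c(cccc2N2CCN(C3COC3)CC2)CN1)[C@H]1CCCc2cccnc21` carries an oxetan-3-yl there, and compound 2 gives 381 nM. Compound 3 `CN(C[C@H]1Cc2c(cccc2N2CCNCC2)CN1)[C@H]1CCCc2cccnc21` carries a hydrogen there, and compound 3 gives 6.08 nM. Among these three numbers compound 3 stands second highest; its nearest neighbour is compound 1, since the step of a 1.4-fold higher number from compound 1 to compound 3 (0.13 log units; within the scatter) lies within the scatter, while its furthest is compound 2, with the step of a 63-fold lower number from compound 2 to compound 3 (1.80 log units; beyond the scatter) well beyond it.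

Compound 4 `CCN1CCN(c2cccc3c2C[C@H](CN(C)[C@H]2CCCc4cccnc42)NC3)CC1` is not yet measured. It differs from compound 3 as follows: ethyl in place of hydrogen on an amine nitrogen in a ring. Within the data shown here, two measured steps bear on this change, both at the same amine nitrogen in a ring: a 1.4-fold higher number from compound 1 to compound 3 (0.13 log units; within the scatter), which is small, and a 63-fold lower number from compound 2 to compound 3 (1.80 log units; beyond the scatter), which is large. Ethyl, with no ring and no acceptors, is a far smaller addition than either group removed in those steps, so no step beyond the scatter is expected here; the step from compound 3 to compound 4 is estimated at a 1.3-fold higher number from compound 3 to compound 4 (0.12 log units; within the scatter). Compound 4 is therefore expected to give about 8 nM, likely between 3 nM and 25 nM.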

Compound 4, half-maximal inhibitory concentration: 13.8 nM
The estimate for compound 4 lay 1.7-fold (0.24 log units) below the measured number, within the range that was stated.
By their numbers in this assay, from the lowest: compounds 1 and 3 (each within the scatter of the next); then compound 4; then compound 2.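

In this assay, ethyl on the amine nitrogen in a ring gives a 2.3-fold higher number from compound 3 to compound 4 (0.36 log units; beyond the scatter), so a group with no ring and only 2 carbon atoms already moves the number beyond the scatter, which a 1.4-fold higher number from compound 1 to compound 3 (0.13 log units; within the scatter) alone did not suggest for this position. The order also does not follow the size of the added group: ethyl gives a 3.1-fold higher number from compound 1 to compound 4 (0.49 log units; beyond the scatter), and compound 1, with its larger (pyridin-2-yl)methyl, goes against any trend of larger groups giving higher numbers, while a 28-fold lower number from compound 2 to compound 4 (1.44 log units; beyond the scatter) shows that the large rise seen with oxetan-3-yl is not shared by every group placed on this nitrogen. Nothing given with these compounds accounts for this order.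

As far as these compounds go, it remains open whether a methyl or a longer chain such as propyl would stay close to ethyl or climb towards oxetan-3-yl. Equally open, from the compounds shown here alone, is how a chain ending in a hydroxyl, an amine or a carboxylic acid, or an acetyl on the same nitrogen, would compare, and whether a benzyl would match (pyridin-2-yl)methyl.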